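The compounds below may be only part of what the source reports. "The series", "measured", "known", "first", "only" and "open" are said of these compounds alone.

Values so far in a physicochemical assay for lipophilicity, measured as octanol-water partition; on this read-out lower numbers stand for lower lipophilicity and higher numbers for higher lipophilicity

- Compound 1 `CCCCCc1cn(CC=C(C)C)nn1` gives 3.46
- Compound 2 `CCCc1cn(C/C=C(/C)CCC=C(C)C)nn1` gives 4.05

Compound 2 stands highest of these two numbers, and its gap to compound 1 lies beyond the usual scatter of repeated measurements. The two compounds differ in more than one place, so that gap does not give the size of any single change.

Compound 3 `CCCCCc1cn(C/C=C(/C)CCC=C(C)C)nn1` comes from compound 2 through one change: ethyl in place of hydrogen on a saturated chain carbon, three bonds along the chain from an aromatic carbon with ethyl in place of hydrogen on a saturated chain carbon, three bonds along the chain from an aromatic carbon. The same difference reads as propyl to pentyl.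

For the measured compounds named here, no measured pair isolates this change, so the expectation rests on the structural change alone. An upward move in this assay is expected, beyond the scatter, starting from compound 2 at 4.05 as the reference. The estimated size is a number 0.90 log units higher from compound 2 to compound 3 (beyond the scatter) in that upward direction. For compound 3 the estimated value is 4.95 with an expected range from 4.55 to 5.35 as the working figure.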

Compound 3, partition coefficient: 5.45
The estimate for compound 3 lay 0.50 log units below the measured number; measured number above the stated range.
By their numbers in this assay, from the lowest: compound 1; then compound 2; then compound 3.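

Notes on the series: in this assay, lengthening propyl to pentyl, with ethyl in place of hydrogen on a saturated chain carbon, three bonds along the chain from an aromatic carbon, gives a number 1.40 log units higher from compound 2 to compound 3 (beyond the scatter), the first single-change reading at this position, and it places compound 3 highest of the three. With pentyl held constant, the other change, 3-methylbut-2-en-1-yl in place of hydrogen on a saturated chain carbon bound to a double-bonded chain carbon, gives a number 1.99 log units higher from compound 1 to compound 3 (beyond the scatter), so a large upward step in this read-out is seen for a change at each of two different places in the series. Nothing at hand accounts for the size of either step.

From the compounds shown here alone, each step rests on a single pair, so it remains open whether either size would hold with a different partner group elsewhere on the shared core. Also open, going by these compounds, is whether a longer chain such as heptyl in place of pentyl would continue the upward move, and where the number would fall with an amine or a carboxylic acid in place of that chain.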